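The source may report more compounds than this note shows. Statements on the series, on what has been measured and on what is new or still open speak of the compounds shown alone.

Working notes on the series. For the measured compounds named here, in an ADME assay on the whole organism for cytotoxicity, with Artemia salina as the target, with a stated time of 24 h (on this read-out higher numbers stand for an effect only at larger amounts of compound and lower numbers for an effect already at smaller amounts), compound 1 `Cc1ccc(/C=C/C(=O)c2ccccc2NC(=O)NS(=O)(=O)c2ccc(C)cc2)cc1` gives 15.3 ug/mL, the highest of the three numbers measured so far, though every other compound lies within the scatter of it. Compound 2 `COc1ccc(/C=C/C(=O)c2ccccc2NC(=O)NS(=O)(=O)c2ccc(C)cc2)cc1OC` gives 12.9 ug/mL in this assay, and compound 3 `Cc1ccc(S(=O)(=O)NC(=O)Nc2ccccc2C(=O)/C=C/c2ccccc2Cl)cc1` gives 12.8 ug/mL. The steps from compound 1 are a 1.2-fold lower number from compound 1 to compound 2 (0.07 log units; within the scatter) and a 1.2-fold lower number from compound 1 to compound 3 (0.08 log units; within the scatter); between the two variants the step is a 1.0-fold lower number from compound 2 to compound 3 (0.00 log units; within the scatter). All three replacements of the aryl group on the double-bonded chain carbon therefore leave the read-out essentially unchanged.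

Compound 4 `Cc1ccc(S(=O)(=O)NC(=O)Nc2ccccc2C(=O)/C=C/c2ccc(Cl)cc2)cc1` has not yet been measured. It differs from compound 1 by chloro in place of methyl on an aromatic carbon, that is, 4-methylphenyl to 4-chlorophenyl, a smaller alteration than any of the measured aryl exchanges. Since the larger changes to 3,4-dimethoxyphenyl and to 2-chlorophenyl gave a 1.2-fold lower number from compound 1 to compound 2 (0.07 log units; within the scatter) and a 1.2-fold lower number from compound 1 to compound 3 (0.08 log units; within the scatter), no step beyond the scatter is expected here either. Compound 4 is accordingly estimated at 13.5 ug/mL in this assay, with a range from 7 ug/mL to 27 ug/mL, which corresponds to an expected step of a 1.1-fold lower number from compound 1 to compound 4 (0.05 log units; within the scatter).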

Compound 4, concentration for half-maximal effect: 6.92 ug/mL
Beside the measured number, compound 4's estimate is 2.0-fold (0.29 log units) above it; the whole stated range lies above it.
By their numbers in this assay, from the lowest: compounds 4, 3, 2 and 1 (each within the scatter of the next, the first and the last beyond it).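

In this assay, for the compounds shown here, chloro in place of methyl on an aromatic carbon, para to a large group, gives the first step that lies beyond the scatter, though a modest one (a 2.2-fold lower number from compound 1 to compound 4 (0.34 log units; beyond the scatter)). The aryl exchanges that lead to compound 4 from the other two variants stay within the scatter (a 1.8-fold lower number from compound 3 to compound 4 (0.27 log units; within the scatter); a 1.9-fold lower number from compound 2 to compound 4 (0.27 log units; within the scatter)), so compound 4 is set apart from compound 1 only, and 4-chlorophenyl cannot be separated from 2-chlorophenyl or 3,4-dimethoxyphenyl on these numbers. Nothing available bears on the reason for the step from methyl to chloro.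

The compounds shown leave open whether bromo, an amine or a carboxylic acid at this place would stand with chloro, with methyl or apart from both. Going by these compounds alone, they also leave open whether the step seen here on the shared core would recur with the same exchange elsewhere, as this single pair is the only direct exchange of methyl for chloro.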